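A few compounds are considered here, and "the series" means these few. Any claim that something is new, unique, unknown or untested is made for them only; others in the source may bear on it.

Compound 1, `O[C@@H](c1ccccc1)[C@H]1CO[C@H](c2ccccc2)[C@@H](C/C=C/c2cccc(F)c2)C1`, gives 8380 nM in a functional assay on HeLa cells (Homo sapiens) for cytotoxicity, read by WST assay, with a stated time of 48 h; on this read-out higher numbers stand for weaker inhibition and lower numbers for stronger inhibition.
Compound 2, `COc1cccc([C@H](O)[C@H]2CO[C@@H](c3ccc(OC)c(OC)c3)[C@H](C/C=C/c3ccc(OC)c(OC)c3)C2)c1`, gives 18600 nM in this assay.

Of these two measured compounds, compound 1 has the lower number in this assay, and the gap to compound 2, which sits at the higher number, lies beyond the usual scatter of repeated measurements. Compound 3, `Oc1ccccc1/C=C/C[C@H]1C[C@@H]([C@@H](O)c2ccccc2)CO[C@@H]1c1ccccc1`, has not yet been measured. It differs from compound 1 in a single place: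

2-hydroxyphenyl in place of 3-fluorophenyl on a double-bonded chain carbon bound to a double-bonded chain carbon

Among the compounds with values here, no pair of measured compounds differs in just this way, so there is no measured step to lean on, and compound 2 differs from compound 1 in several places at once, which makes it no guide for this one change. Within the data shown here, with only a single exchanged group on the outer aromatic ring of the chain, the expected step in this assay is a 1.2-fold higher number from compound 1 to compound 3 (0.08 log units; within the scatter), a shift that may not rise beyond the scatter, with the direction uncertain. On that basis compound 3 is expected to give about 10000 nM, with a plausible range from 4000 nM to 30000 nM.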

Compound 3, half-maximal inhibitory concentration: 21800 nM
Compound 3: middle estimate off by 2.2-fold (0.34 log units), on the low side; the measured number falls inside the stated range.
By their numbers in this assay, from the lowest: compound 1; then compounds 2 and 3 (each within the scatter of the next).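

In this assay, within the data shown here, placing 2-hydroxyphenyl in place of 3-fluorophenyl on the chain gives a 2.6-fold higher number from compound 1 to compound 3 (0.42 log units; beyond the scatter) and is the first single change read at this place, showing that the group carried there can move the result. Since a higher number stands for weaker inhibition, this exchange weakens the effect on the cells, although the step is modest and both groups have the same number of heavy atoms. The entering group has a hydrogen-bond donor and acceptor that the leaving group lacks, but no measurement shown ties the step to that difference or to any other property of the two groups.

Among these compounds, with only this one step at the place, it stays open whether the weaker result goes with gaining the hydroxyl group, losing the fluorine, or the different ring positions of these two groups. An unsubstituted phenyl ring would help separate these possibilities, while an amine or a carboxylic acid on that ring would show how far the trend extends beyond these two groups.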